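The source may hold more compounds than are shown below. What is called first, only, known or untested is meant among the compounds shown, and "the series" means these compounds.

In a functional assay on HCT-116 cells (Homo sapiens) for inhibition, read by luminescence and resazurin assay, with a stated time of 3 days (on this read-out higher numbers stand for weaker inhibition and lower numbers for stronger inhibition), compound 2 `CNc1nc(NCc2ccc(NC(=O)c3ccc(F)cc3)cc2)c2ccccc2n1` gives 1600 nM. Compound 1 `CCNc1nc(NCc2ccc(NC(=O)c3ccc(F)cc3)cc2)c2ccccc2n1` carries methyl in place of hydrogen on a saturated chain carbon bound to a nitrogen on an aromatic ring, and in this assay compound 1 gives 1400 nM, the step being a 1.1-fold lower number from compound 2 to compound 1 (0.06 log units; within the scatter). Compound 3 `CCCNc1nc(NCc2ccc(C(=O)Nc3ccc(F)cc3)cc2)c2ccccc2n1` rests on another core, and the difference between the two cores is not broken down here; in this assay compound 3 gives 1500 nM. Compound 4 `CCCCNc1nc(NCc2ccc(C(=O)Nc3ccc(F)cc3)cc2)c2ccccc2n1` has not yet been measured. It differs from compound 3 by methyl in place of hydrogen on a saturated chain carbon, three bonds along the chain from a nitrogen on an aromatic ring, the same kind of change as that from compound 2 to compound 1, though here the saturated chain carbon is three bonds along the chain from a nitrogen on an aromatic ring rather than bound to it. Because a 1.1-fold lower number from compound 2 to compound 1 (0.06 log units; within the scatter) lies within the scatter, compound 4 is expected to give about 1400 nM, estimated between 700 nM and 2800 nM, which means an expected step of a 1.1-fold lower number from compound 3 to compound 4 (0.03 log units; within the scatter).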

Compound 4, half-maximal inhibitory concentration: 1400 nM
Estimate against measurement, compound 4: no gap at the digits printed, within the range that was stated.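

In this assay the added methyl gives a 1.1-fold lower number from compound 3 to compound 4 (0.03 log units; within the scatter), and set beside the earlier step, the change reads alike on the two cores: the same change on two cores in this assay, a 1.1-fold lower number (0.06 log units; within the scatter) from compound 2 to compound 1 and a 1.1-fold lower number (0.03 log units; within the scatter) from compound 3 to compound 4, 1.1-fold (0.03 log units) apart, within the scatter of two such steps. This shows that on these two cores the change leaves the number within the scatter both times, even though the methyl enters at a different place on the chain in each pair. It does not show that the two cores respond alike in general, since a step within the scatter on each core gives no sizeable effect to compare, and only one pair per core is shown.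

As far as these compounds go, it remains open whether a chain longer than butyl, a branched chain, or a chain ending in an amine or a carboxylic acid would give a step beyond the scatter. From the compounds shown here alone, it also remains open whether such a step would carry from one core to the other.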